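A few compounds are considered here, and "the series" means these few. Any claim that something is new, unique, unknown or untested is made for them only; others in the source may bear on it.

Of the compounds shown here, two built on a shared core have been tested in a functional assay on the whole organism (Tail, strain ICR) with Mus musculus as the target, in the tail flick test, with a stated time of 30 min, at a dose of 25 umol/kg by the oral route; a lower number here means a weaker effect, a higher number a stronger effect of the compound at the dose given. Compound 1 `O=C(CN(c1nc(Cl)nc2[nH]cnc12)C1CC1)N[C@@H](CO)C(=O)O` carries a hydroxy on a saturated chain carbon, two bonds along the chain from an amide-type nitrogen and a carbonyl carbon, and in this assay compound 1 gives 38.7%. Compound 2 `CC(C)C[C@H](NC(=O)CN(c1nc(Cl)nc2[nH]cnc12)C1CC1)C(=O)O` carries an isopropyl at that place; in this assay compound 2 gives 23.4%, the lower of the two numbers. For the measured compounds named here, the single measured step, a number 15.3 percentage points lower from compound 1 to compound 2 (beyond the scatter), is the only guide there is.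

Compound 3 `C[C@H](NC(=O)CN(c1nc(Cl)nc2[nH]cnc12)C1CC1)C(=O)O` is the next compound, and it differs from compound 2 as follows: hydrogen in place of isopropyl on a saturated chain carbon, two bonds along the chain from an amide-type nitrogen and a carbonyl carbon The isopropyl that arrived in the step to compound 2, together with a drop in activity, now leaves again, although a hydrogen rather than a hydroxy takes its place, so the earlier step bears on this one only loosely. A partial return toward the level of compound 1 is expected, with a number 8.6 percentage points higher from compound 2 to compound 3 (within the scatter) as the estimated step. Compound 3 is therefore estimated to give 32%, within a range from 18% to 48%.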

Compound 3, a percentage reported as activity, at one dose (the size of the read-out at that dose, not a potency): 48.1%
For compound 3 the middle estimate is 16.1 percentage points below the measured one; the measured number lies above the stated range.
By their numbers in this assay, from the lowest: compound 2; then compounds 1 and 3 (each within the scatter of the next).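

Set against the earlier step, this result shows that the low number of compound 2 goes with the isopropyl at this place: in this assay, replacing it with hydrogen gives a number 24.7 percentage points higher from compound 2 to compound 3 (beyond the scatter). Replacing the hydroxy of compound 1 with hydrogen gives a number 9.4 percentage points higher from compound 1 to compound 3 (within the scatter), so hydroxy and hydrogen cannot be told apart at this place in this assay, and the hydroxy is shown not to be needed for the effect seen at this dose. Among these three compounds, then, only the isopropyl of compound 2 sets a number apart, and nothing available explains why the isopropyl has this effect.

Going by these compounds, it remains open whether any carbon group larger than hydrogen at this place lowers the number or whether the drop is particular to the isopropyl, a question that an ethyl or a longer chain would help to answer. On these data alone, it is also open how an amine or a phenyl ring at this place would compare with the hydroxy and the hydrogen.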